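Shrinking the Ester Group on a Nucleoside-like Core

The source may hold more compounds than are shown below. What is called first, only, known or untested is meant among the compounds shown, and "the series" means these compounds.

Of the compounds shown here, two sharing one core have been tested in an ADME assay on Vero cells (Chlorocebus sabaeus) for cytotoxicity, read by MTT assay, with a stated time of 3 days; on this read-out lower numbers stand for stronger inhibition and higher numbers for weaker inhibition. Compound 1 (`Cc1cn([C@H]2CO[C@@H](COC(=O)C(C)(C)C)O2)c(=O)[nH]c1=O`) carries a tert-butyl on the carbonyl carbon of its ester, and in this assay compound 1 gives 18100 nM. Compound 2 (`Cc1cn([C@H]2CO[C@@H](COC(=O)C3CCCCC3)O2)c(=O)[nH]c1=O`) carries a cyclohexyl at the same position. For compound 2 the assay reports only a limit, > 100000 nM, so no exact number is known for it. The step from one to the other is an at least 5.5-fold higher number from compound 1 to compound 2 (0.74 log units; beyond the scatter), because of the limit of > 100000 nM in this assay, at which 1 of the 2 values shown sits, the true size of that step cannot be fixed.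

Compound 3 (`CC(=O)OC[C@@H]1OC[C@H](n2cc(C)c(=O)[nH]c2=O)O1`) is the next variation: methyl in place of cyclohexyl on a carbonyl carbon. Among the measured compounds shown here, the only step measured so far runs from a small branched group to a larger ring and brings a higher number; compound 3 moves the other way, to the smallest possible group, so a number lower than the limit of compound 2 and nearer that of compound 1 is expected, an at least 2.5-fold lower number from compound 2 to compound 3 (0.39 log units; beyond the scatter). The expected value for compound 3 in this assay is therefore 40000 nM, within a range from 8000 nM to 150000 nM.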

Compound 3, half-maximal inhibitory concentration: > 100000 nM
Compound 3 was reported as a limit; the forecaster's own chance of this, stated with the estimate: 40%; middle value at least 2.5-fold (0.39 log units) away from the limit.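

In this assay compound 3 gives > 100000 nM, which is a limit and not a number. Methyl in place of tert-butyl on the carbonyl carbon brings an at least 5.5-fold higher number from compound 1 to compound 3 (0.74 log units; beyond the scatter), so among these three compounds, moving away from tert-butyl gives a higher number whether the new group is the larger cyclohexyl of compound 2 or the smaller methyl of compound 3, and the read-out does not follow group size in a single direction. The step between compound 2 and compound 3 cannot be read, because both sit at the same limit: the limit of > 100000 nM in this assay, at which 2 of the 3 values shown sit.

Since only compound 1 has an exact value, these compounds leave open whether the tert-butyl stands alone or whether other branched groups, such as isopropyl, would also give a number within the range of the assay. Also open, from the compounds shown here alone, is where a longer chain such as n-butyl or an aromatic ring such as phenyl would fall at this position, and how far compound 2 and compound 3 truly lie from compound 1.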